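Sulfur-linked heteroaryl swap on the shared core

The compounds below may be only part of what the source reports. "The series", "measured", "known", "first", "only" and "open" are said of these compounds alone.

Measured so far:
compound 1, `Cn1c(-c2ccc(NC(=O)CSc3nc4ccccc4o3)cc2)nc(-c2ccccc2)c1-c1ccccc1`, 24.8%
compound 2, `Cn1c(-c2ccc(NC(=O)CSc3nc4cc(Cl)ccc4o3)cc2)nc(-c2ccccc2)c1-c1ccccc1`, 11.9%
compound 3, `Cn1c(-c2ccc(NC(=O)CSc3nc4ccccc4s3)cc2)nc(-c2ccccc2)c1-c1ccccc1`, 9.8%

In a functional assay on HT-29 cells (Homo sapiens) for cytotoxicity, read by MTT assay, with a stated time of 24 h, tested at 0.64 ug/mL (a lower number here means a weaker effect, a higher number a stronger effect of the compound at the concentration tested), compound 2 stands second highest of the three numbers. Its nearest neighbour is compound 3, with a number 2.1 percentage points lower from compound 2 to compound 3 (within the scatter), a step within the scatter; the furthest is compound 1, and the step of a number 12.9 percentage points lower from compound 1 to compound 2 (beyond the scatter) lies beyond the scatter. Compound 3 also sits well below compound 1, with a number 15 percentage points lower from compound 1 to compound 3 (beyond the scatter).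

The unmeasured compound 4, `Cn1nnnc1SCC(=O)Nc1ccc(-c2nc(-c3ccccc3)c(-c3ccccc3)n2C)cc1`, differs from compound 2 on the sulfur: 1-methyl-1H-tetrazol-5-yl in place of 5-chloro-1,3-benzoxazol-2-yl on a sulfur.

Among the compounds with values here, two measured steps bear on this. Exchanging one bicyclic heteroaryl on the sulfur for another gave a number 15 percentage points lower from compound 1 to compound 3 (beyond the scatter), a modest loss, while the step of a number 2.1 percentage points lower from compound 2 to compound 3 (within the scatter) from the chlorinated analogue stayed within the scatter. Both replacements on the sulfur therefore ended up near the low end of the series, and compound 2 already sits there. Within the data shown here, no measured step covers a small monocyclic heteroaryl on the sulfur, so the expectation rests on this pattern alone: the step of a number 1.9 percentage points lower from compound 2 to compound 4 (within the scatter) is expected to remain within the scatter or fall slightly lower, with no rise to the level of compound 1 anticipated.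

For compound 4 the expected value in this assay is 10%, within a range from 2% to 24%.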

Compound 4, a percentage reported as activity, at one concentration (the size of the read-out at that concentration, not a potency): 38%
The estimate for compound 4 lay 28 percentage points below the measured number, outside the stated range (above it).
By their numbers in this assay, from the lowest: compounds 3 and 2 (each within the scatter of the next); then compound 1; then compound 4.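

On the sulfur, the change to 1-methyl-1H-tetrazol-5-yl moves the read-out upward in this assay against all three bicyclic groups: there is a number 26.1 percentage points higher from compound 2 to compound 4 (beyond the scatter) and a number 28.2 percentage points higher from compound 3 to compound 4 (beyond the scatter) and also a number 13.2 percentage points higher from compound 1 to compound 4 (beyond the scatter). The earlier compounds shown here showed only steps downward from compound 1, so this position had not yet been seen to go above the level of the unsubstituted 1,3-benzoxazol-2-yl group; with a single five-membered aromatic ring in place of the bicyclic groups, compound 4 now stands highest of the four. Nothing measured here accounts for this rise.

A single monocyclic example cannot separate the contribution of the tetrazole ring from that of its methyl group, so the 1H-tetrazol-5-yl group without the methyl, or a 1-methyl-1H-imidazol-2-yl group on the same sulfur, would be the direct comparisons. On these data alone, whether the order holds beyond this single concentration in this assay also stays open, since the read-out is the size of the effect at that concentration and not a potency.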